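This account rests on a few compounds, and the source may have more. Where it says the series, first, only, none or still open, it means among the compounds named here.

Measured so far:
compound 1 `Cc1cc(-c2nn3c(-c4ccoc4C)nnc3s2)c2ccccc2n1`: 18.6%
compound 2 `Cc1occc1-c1nnc2sc(Cc3c[nH]c4ccccc34)nn12`: 26.5%
compound 3 `COc1ccc(Cl)c(-c2nnc3n2NC(c2ccco2)S3)c1`: 23.1%

In a functional assay on the whole organism (strain Wistar Albino) for inhibition, with Rattus norvegicus as the target, read by paw edema, with a stated time of 3 h, at a dose of 20 mg/kg (on this read-out lower numbers stand for less inhibition and higher numbers for more inhibition at the one dose given (going by the name of the read-out)), compound 3 gives 23.1%, the second highest of the three numbers. Its nearest neighbour is compound 2 and its furthest is compound 1, and both gaps lie within the usual scatter of this read-out, so the three measured compounds cannot be separated from one another on these numbers. Going by the values given here, no pair of measured compounds differs in a single place, and compounds 1 and 2 do not share the core of compound 3, so no measured step speaks directly to a change on that core.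

Compound 4 `COc1ccc(Cl)c(-c2nnc3n2NC(c2cccn2C)S3)c1` is the next to be measured in this assay. It differs from compound 3 in one place: 1-methyl-1H-pyrrol-2-yl in place of furan-2-yl on a saturated ring carbon. The exchange keeps one five-membered aromatic ring with one hetero atom and the same count of hydrogen-bond donors and acceptors on that saturated ring carbon.

Among the compounds with values here, with no measured step of this kind to go by, the expected step from compound 3 to compound 4 in this assay is a number 0.9 percentage points higher from compound 3 to compound 4 (within the scatter), in no particular direction and not beyond the scatter. Compound 4 is therefore expected to give 24%, with a range of 12% to 36%.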

Compound 4, a percentage reported as inhibition, in the whole organism at one dose (the size of the read-out at that dose, not a potency): 18.5%
Compound 4: the middle estimate sits 5.5 percentage points above what was measured, within the range that was stated.
By their numbers in this assay, from the lowest: compounds 4, 1, 3 and 2 (each within the scatter of the next).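

In this assay, going by these compounds alone, the exchange of furan-2-yl for 1-methyl-1H-pyrrol-2-yl on the saturated ring carbon gives a number 4.6 percentage points lower from compound 3 to compound 4 (within the scatter), the first single-place comparison on the core of compound 3. At this position, therefore, the two five-membered aromatic rings, each with one hetero atom, cannot be separated on this read-out at the one dose given, and the ring oxygen and the methylated ring nitrogen give no resolved difference here. Nothing measured alongside these numbers bears on this step, so the step stands as an observation without an explanation.

The compounds shown leave open whether a group of another kind on the same saturated ring carbon, such as an amine, a carboxylic acid or a longer alkyl chain, would give a number beyond the scatter of compound 3. Within the data shown here, they also leave open whether the same exchange would read alike on a different core or at another dose, as this pair gives only one comparison at one dose and one time point.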